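Replacing the methoxyphenyl arm of an oxazole ketone by methylpyridinyl

The source may hold more compounds than are shown below. What is called first, only, known or untested is meant among the compounds shown, and "the series" means these compounds.

Measured so far:
Compound 1, `CN(C)C(=O)c1cnc(C(=O)CCCCCCc2ccccc2)o1`: in an assay on HEK-293T cells for inhibition of diacylglycerol lipase-alpha (Homo sapiens), read by colorimetric assay (on this read-out higher numbers stand for weaker inhibition and lower numbers for stronger inhibition), compound 1 gives > 10000 nM, a limit of the assay.
Compound 2, `COc1cnc(C(=O)CCCCCCc2ccccc2)o1`: in this assay compound 2 gives > 10000 nM, again a limit.
Compound 3, `COc1ccc(-c2cnc(C(=O)CCCCCCc3ccccc3)o2)cc1`: in this assay compound 3 gives > 10000 nM, also a limit.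

Compound 3 therefore stands at the limit, where (the limit of > 10000 nM in this assay, at which 3 of the 3 values shown sit); no number separates it from its two companions. The new compound 4, `Cc1ccc(-c2cnc(C(=O)CCCCCCc3ccccc3)o2)nc1`, differs from compound 3 in one place: 5-methylpyridin-2-yl in place of 4-methoxyphenyl on an aromatic carbon. Among the measured compounds shown here, the steps that bear on this change, a step that the two limits leave unreadable from compound 1 to compound 3 and a step that the two limits leave unreadable from compound 2 to compound 3, together with a step that the two limits leave unreadable from compound 1 to compound 2, are all unreadable, so no measured step tells in which direction, or whether at all, activity moves in this assay. Compound 4 is expected to give 12000 nM, with a range from 3000 nM to 50000 nM, and most likely only a limit again. The expected step from compound 3 is a step that the limit leaves unreadable from compound 3 to compound 4.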

Compound 4, half-maximal inhibitory concentration: > 10000 nM
Compound 4: no number, only a limit (the forecaster's own chance of this, stated with the estimate: 80%); the middle value does not contradict the limit.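

In this assay, among the compounds shown here, compound 4 also gives only a limit, so no step linking it to compound 1, compound 2 or compound 3 can be read: the limit of > 10000 nM in this assay, at which 4 of the 4 values shown sit. The compounds shown leave open whether any of these changes to the shared core moves inhibition at all, and how strong any of the four compounds is.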